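The source may hold more compounds than are shown below. What is called first, only, known or untested is meant among the compounds shown, and "the series" means these compounds.

Measured so far:
compound 1 `O=C(Nc1cccc(/C=C/C(=O)c2nc3ccccc3[nH]2)c1)c1ccc(Br)cc1` — 2230 nM
compound 2 `O=C(Nc1cccc(/C=C/C(=O)c2nc3ccccc3[nH]2)c1)c1cc(Cl)cc(Cl)c1` — 1650 nM

In a functional assay on HCT-116 cells (Homo sapiens) for antiproliferative activity, read by MTT assay, with a stated time of 48 h (on this read-out higher numbers stand for weaker inhibition and lower numbers for stronger inhibition), compound 2 gives 1650 nM; compound 1 stands within the scatter of it, the step being a 1.4-fold lower number from compound 1 to compound 2 (0.13 log units; within the scatter). Compound 3 `Cc1cc(C)cc(C(=O)Nc2cccc(/C=C/C(=O)c3nc4ccccc4[nH]3)c2)c1` differs from compound 2 by 3,5-dimethylphenyl in place of 3,5-dichlorophenyl on a carbonyl carbon. For the measured compounds named here, the only step on this phenyl, a 1.4-fold lower number from compound 1 to compound 2 (0.13 log units; within the scatter), exchanged one halogen pattern for another and stayed within the scatter; no measured step exchanges chlorine for methyl, so nothing bears directly on it. No step beyond the scatter is expected: a 1.2-fold higher number from compound 2 to compound 3 (0.08 log units; within the scatter). Compound 3 is estimated at 2000 nM, expected between 900 nM and 4500 nM.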

Compound 3, half-maximal inhibitory concentration: 1550 nM
For compound 3 the middle estimate is 1.3-fold (0.11 log units) above the measured one; the range from low to high includes it.
By their numbers in this assay, from the lowest: compounds 3, 2 and 1 (each within the scatter of the next).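

In this assay the exchange of chlorine for methyl on this phenyl gives a 1.1-fold lower number from compound 2 to compound 3 (0.03 log units; within the scatter) and the exchange of 4-bromophenyl for 3,5-dimethylphenyl gives a 1.4-fold lower number from compound 1 to compound 3 (0.16 log units; within the scatter) as its counterpart. The range of groups on this carbonyl carbon now spans halogen and methyl substituents, yet compounds 1, 2 and 3 all stand within the scatter of one another. Nothing on hand offers an explanation for this. On these data alone, whether an amine or a carboxylic acid on this phenyl would move the number beyond the scatter stays open. The same holds for a longer alkyl chain in place of the phenyl.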